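Fatty-acid esters on a shared core: chain extension step

The source may hold more compounds than are shown below. What is called first, only, known or untested is meant among the compounds shown, and "the series" means these compounds.

All numbers below come from a functional assay on HeLa cells (Homo sapiens) for cytotoxicity, read by cell counting, with a stated time of 48 h; on this read-out higher numbers stand for an effect only at larger amounts of compound and lower numbers for an effect already at smaller amounts.
Compound 1, `CCCCCCCCCCCCCCCCCCCCCC(=O)OC[C@H]1O[C@@H](n2ccc(N)nc2=O)[C@@H](O)[C@@H]1O`: 0.04 ug/mL
Compound 2, `CCCCCC(=O)O[C@H]1[C@H](O)[C@H](n2ccc(N)nc2=O)O[C@@H]1CO`: 0.05 ug/mL
Compound 3, `CCCCCCCCCCCCCCCCCC(=O)OC[C@H]1O[C@@H](n2ccc(N)nc2=O)[C@@H](O)[C@@H]1OC(=O)CCCCCCCCCCCCCCCCC`: 10 ug/mL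

Compound 2 carries the second highest of the three numbers. Its nearest neighbour is compound 1, and that gap lies within the scatter, so no order between the two can be claimed; compound 3 gives a far higher number, beyond the scatter. Compound 1 and compound 2 differ in more than one place, so their closeness gives no single clean reading.

Compound 4, `CCCCCCCC(=O)O[C@H]1[C@H](O)[C@H](n2ccc(N)nc2=O)O[C@@H]1CO`, is not yet measured. It differs from compound 2 by ethyl in place of hydrogen on a saturated chain carbon, five bonds along the chain from a carbonyl carbon. For the measured compounds named here, no measured pair differs by one such change, so the size of this step cannot be taken from the data. The step is expected to stay within the scatter: no change at the digits printed from compound 2 to compound 4 (within the scatter). In this assay compound 4 is expected at 0.05 ug/mL, with a range from 0.015 ug/mL to 0.2 ug/mL.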

Compound 4, concentration for half-maximal effect: 0.1 ug/mL
Compound 4: the middle estimate sits 2.0-fold (0.30 log units) below what was measured; the range from low to high includes it.
By their numbers in this assay, from the lowest: compounds 1, 2 and 4 (each within the scatter of the next, the first and the last beyond it); then compound 3.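

In this assay, ethyl in place of hydrogen on a saturated chain carbon, five bonds along the chain from a carbonyl carbon, gives a 2.0-fold higher number from compound 2 to compound 4 (0.30 log units; within the scatter) and so shows no change that can be told from the scatter. This is the only single-place step among the compounds shown, so it gives the size of this one change at this one place and no trend along the chain. No evidence on the cause of this step is at hand.

Going by these compounds, whether a longer chain, or an amine on the chain, at this place would stay within the scatter of compound 2 remains open.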